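Swapping a fluorinated carbamate tail for an oxetane

A few compounds are considered here, and "the series" means these few. Any claim that something is new, unique, unknown or untested is made for them only; others in the source may bear on it.

The two measured compounds share one core and differ only in the group on an oxygen next to a carbonyl group. Compound 1 `Cc1nc(S(C)(=O)=O)ccc1Oc1ncnc(OC2CCN(C(=O)OC(C)(C)CF)CC2)c1F` carries a 1-(fluoromethyl)-1-methylethyl group there, and in a functional assay on isolated protein for inhibition of Glucose-dependent insulinotropic receptor (Homo sapiens), read by HTRF and cAMP accumulation (a lower number here means that less compound is needed, a higher number that more compound is needed for the effect), compound 1 gives 19.9 nM. Compound 2 `Cc1nc(S(C)(=O)=O)ccc1Oc1ncnc(OC2CCN(C(=O)O[C@@H](C)C(F)(F)F)CC2)c1F` carries a 1-(trifluoromethyl)ethyl group instead, and in this assay compound 2 gives 9.86 nM. That step, a 2.0-fold lower number from compound 1 to compound 2 (0.30 log units; within the scatter), is the only measured one and lies within the scatter, so compound 2 has the lowest of the two numbers without standing apart from compound 1. Compound 3 `Cc1nc(S(C)(=O)=O)ccc1Oc1ncnc(OC2CCN(C(=O)OC3COC3)CC2)c1F` is not yet measured; its change from compound 2 is oxetan-3-yl in place of 1-(trifluoromethyl)ethyl on an oxygen next to a carbonyl group. For the measured compounds named here, the one measured step exchanged one fluorinated alkyl group for another and moved nothing beyond the scatter, so it says little about replacing the fluorinated group with a small ring. Both measured compounds carry fluorine in this group and compound 3 carries none, so the estimate stays cautious. Compound 3 is expected to give 25 nM, within 8 nM to 80 nM, a step of a 2.5-fold higher number from compound 2 to compound 3 (0.40 log units; beyond the scatter) that is expected to be modest.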

Compound 3, half-maximal effective concentration: 326 nM
For compound 3 the middle estimate is 13-fold (1.12 log units) below the measured one; the measured number lies above the stated range.
By their numbers in this assay, from the lowest: compounds 2 and 1 (each within the scatter of the next); then compound 3.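

In this assay, the group on an oxygen next to a carbonyl group matters far more than the first exchange suggested: oxetan-3-yl in place of 1-(trifluoromethyl)ethyl brings a 33-fold higher number from compound 2 to compound 3 (1.52 log units; beyond the scatter) and oxetan-3-yl in place of 1-(fluoromethyl)-1-methylethyl brings a 16-fold higher number from compound 1 to compound 3 (1.21 log units; beyond the scatter) in this same comparison. Compound 1 and compound 2, with their two fluorinated alkyl groups, lie within the scatter of each other, while compound 3 stands clearly apart from both, so this position does not accept every small group equally. The change replaces an open fluorinated chain with a four-membered ring holding one oxygen, and nothing measured here accounts for the much higher number.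

Fluorine, the open chain and the ring oxygen all change together in these compounds, so it remains open which of them goes with the shift. A plain isopropyl group, with no fluorine, and a cyclobutyl group, with a four-membered ring of carbon alone, would each separate one of these changes from the others.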